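The source may hold more compounds than are shown below. What is called first, only, known or untested is meant among the compounds shown, and "the series" means these compounds.

Compound 3, `CN1CCC(NC(=O)c2cn3ccnc3c(N3CCN(c4ccccn4)CC3)n2)CC1`, is one of two compounds in this set for which a number was obtained in a functional assay on PBL cells (Homo sapiens) for inhibition (a higher number here means a weaker inhibitor, a lower number a stronger inhibitor), where compound 3 gives 37 nM. The other number belongs to compound 1, `c1cn2ccnc2c(-c2ccc(N3CCCC3)nc2)n1`, which in this assay gives 55 nM; the two numbers lie within the usual scatter of each other, so nothing separates them. The third member of the set, compound 2, `c1cn2ccnc2c(N2CCN(C3CCCC3)CC2)n1`, yields only a limit in this assay, > 10000 nM, and no number. Compound 2 is thus the compound that sits at the limit of > 10000 nM in this assay, at which 1 of the 3 values shown sits.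

The unmeasured compound 4, `O=C(NC1CCNC1)c1cn2ccnc2c(N2CCN(c3ccccn3)CC2)n1`, departs from compound 3 in a single place: pyrrolidin-3-yl in place of 1-methylpiperidin-4-yl on an amide-type nitrogen. Put in words, pyrrolidin-3-yl stands in place of 1-methylpiperidin-4-yl on an amide-type nitrogen. Going by the values given here, no step between measured compounds in this set touches that part of the molecule, so there is nothing measured here to set the size of this change; the rest of the structure, including the group on the shared core, is carried over unchanged.

The expectation is therefore that compound 4 moves little, if at all, beyond the scatter in this assay, with no direction favoured. The step that this expectation implies is a 1.6-fold higher number from compound 3 to compound 4 (0.21 log units; within the scatter). Compound 4 is thus estimated at 60 nM, with a likely range from 20 nM to 200 nM.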

Compound 4, half-maximal inhibitory concentration: 118 nM
Beside the measured number, compound 4's estimate is 2.0-fold (0.29 log units) below it, and the stated range covers the measured number.
By their numbers in this assay, from the lowest: compounds 3 and 1 (each within the scatter of the next); then compound 4. At a limit, above all of these: compound 2.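

Going by these compounds alone, at the amide-type nitrogen, the pair gives the first measured step in this set: in this assay, pyrrolidin-3-yl in place of 1-methylpiperidin-4-yl gives a 3.2-fold higher number from compound 3 to compound 4 (0.50 log units; beyond the scatter). The group at this place therefore does register in the number, though the step is modest, and this single exchange changes several things at once: a six-membered ring becomes a five-membered ring, the methyl group is lost, and a hydrogen-bond donor enters where the group that leaves has none. Nothing available bears on the cause of this step, so it cannot be assigned to any one of these differences.

The compounds shown leave open whether the step follows the ring size or the loss of the methyl group, and a piperidin-4-yl or a 1-methylpyrrolidin-3-yl group on the same nitrogen would separate the two. They also leave open how an open-chain amine, such as 2-aminoethyl, would fare at this place, with the rest of the structure kept as it is in compound 3.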